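The source may report more compounds than this note shows. Statements on the series, on what has been measured and on what is new or still open speak of the compounds shown alone.

Compound 1 `O=C(Nc1ccccc1)N1c2ccnn2CC1c1ccccc1` in a functional assay on cells (Neutrophil, Homo sapiens) for inhibition, with a stated time of 10 min (a higher number here means a weaker inhibitor, a lower number a stronger inhibitor), gives > 1000 nM, which is a limit of the assay.
Compound 2 `O=C(Nc1ccc(F)cc1)N1c2ccnn2CC1c1ccccc1` in this assay gives > 1000 nM, again a limit.
Compound 3 `O=C(c1cnn2c1N(C(=O)Nc1ccccc1)C(c1ccccc1)C2)N1CCCCC1` in this assay gives > 1000 nM, also a limit.

The change from compound 1 to compound 2 is fluoro in place of hydrogen on an aromatic carbon and its step reads a step that the two limits leave unreadable from compound 1 to compound 2. The two cores differ by (piperidin-1-yl)carbonyl in place of hydrogen on an aromatic carbon, with the step that the two limits leave unreadable from compound 1 to compound 3. Compound 4 `O=C(c1cnn2c1N(C(=O)Nc1cccc(F)c1)C(c1ccccc1)C2)N1CCCCC1` carries the same kind of change as compound 2, namely (fluoro in place of hydrogen on an aromatic carbon); the place differs in that it is meta to a large group here and para to a large group in compound 2. Because the limit of > 1000 nM in this assay, at which 3 of the 3 values shown sit, holds every shown value, no step among them is readable. The step expected here is a step that the limit leaves unreadable from compound 3 to compound 4, resting on that same limit. For compound 4 the estimate in this assay is 1500 nM, most likely returned as a limit again.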

Compound 4, half-maximal inhibitory concentration: 1.2 nM
Compound 4: middle estimate off by 1300-fold (3.10 log units), on the high side; the whole stated range lies above it.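

On the core of compound 3, fluoro in place of hydrogen gives an at least 830-fold lower number from compound 3 to compound 4 (2.92 log units; beyond the scatter) in this assay, so the change from phenyl to 3-fluorophenyl takes this core from a limit to a measured value. On the core of compound 1 the same kind of change sits at a different place on the ring, and the steps among compounds 1, 2 and 3 cannot be read because all three stand at one limit: the limit of > 1000 nM in this assay, at which 3 of the 4 values shown sit. The result is therefore a large step on one core only, and it gives no size for carrying the change from one core to the other.

Open, as far as these compounds go, is whether 3-fluorophenyl on the core of compound 1, without the (piperidin-1-yl)carbonyl, reaches a readable value. Also open, from the compounds shown here alone, is whether chloro or methoxy in place of the fluoro of compound 4 keeps a step of this size.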